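The source may hold more compounds than are shown below. What is called first, only, known or untested is meant among the compounds shown, and "the series" means these compounds.

Among the measured compounds shown here, in a functional assay on MDA-MB-231 cells (Homo sapiens) for antiproliferative activity, read by MTT assay, with a stated time of 48 h (on this read-out lower numbers stand for stronger inhibition and higher numbers for weaker inhibition), three compounds have numbers so far: compound 1 `CCOC(=O)/C(=C/c1ccccc1)CN1C(=O)[C@@H](OC)[C@H]1c1ccc(Cl)cc1` (11100 nM), compound 2 `COC(=O)/C(=C/c1ccccc1)CN1C(=O)[C@@H](OC)[C@H]1c1ccc(F)cc1` (21800 nM) and compound 3 `CCOC(=O)/C(=C/c1ccccc1)CN1C(=O)[C@@H](OC)[C@H]1c1ccccc1Br` (6860 nM). Compound 3 lies within the usual scatter of compound 1, while compound 2 has a higher number than compound 3 by more than the scatter. Compound 4 `CCOC(=O)/C(=C/c1ccccc1)CN1C(=O)[C@@H](OC)[C@H]1c1ccc(F)cc1` has not been measured yet. It differs from compound 3 in one group, with 4-fluorophenyl in place of 2-bromophenyl on a saturated ring carbon. For the measured compounds named here, one measured step touches this kind of swap: a 1.6-fold lower number from compound 1 to compound 3 (0.21 log units; within the scatter) for 2-bromophenyl in place of 4-chlorophenyl, and that step is small. Going by the values given here, compound 2 (21800 nM) also carries 4-fluorophenyl, but its ester chain differs from that of compound 4, and no measured step isolates that difference. A modest rise in the number therefore seems likelier than a fall, though not clearly beyond the scatter. The expected step is a 1.7-fold higher number from compound 3 to compound 4 (0.24 log units; within the scatter) in size. Compound 4 is estimated at 12000 nM with an expected range from 5500 nM to 26000 nM on this read-out.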

Compound 4, half-maximal inhibitory concentration: 14000 nM
The estimate for compound 4 lay 1.2-fold (0.07 log units) below the measured number; the measured number falls inside the stated range.
By their numbers in this assay, from the lowest: compounds 3, 1, 4 and 2 (each within the scatter of the next, the first and the last beyond it).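

In this assay, 4-fluorophenyl in place of 2-bromophenyl on the saturated ring carbon gives a 2.0-fold higher number from compound 3 to compound 4 (0.31 log units; beyond the scatter) and so only just passes the usual scatter, a first sign that this position can respond to the choice of aryl group. Fluoro in place of chloro on the aromatic carbon gives a 1.3-fold higher number from compound 1 to compound 4 (0.10 log units; within the scatter) and stays within the scatter, so these two halogens cannot be told apart here. Methyl in place of hydrogen on the chain carbon bound to the ester oxygen gives a 1.6-fold lower number from compound 2 to compound 4 (0.19 log units; within the scatter) and also stays within the scatter, so the methyl and ethyl esters cannot be told apart either.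

No evidence is available to explain these steps. On these data alone, it remains open whether the halogen or its place on the ring matters more, which a 4-bromophenyl or 2-fluorophenyl group could help to separate.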